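A few compounds are considered here, and "the series" means these few. Any claim that something is new, unique, unknown or untested is made for them only; others in the source may bear on it.

Measured in a functional assay on DU-145 cells (Homo sapiens) for inhibition, read by trypan blue exclusion, with a stated time of 96 h; on this read-out higher numbers stand for weaker inhibition of growth and lower numbers for stronger inhibition of growth:
- compound 1 `Cc1ccc(CS(=O)(=O)/C(=C/c2ccc(Br)cc2)C(=O)c2ccc(Cl)cc2)cc1`: 25000 nM
- compound 2 `COc1ccc(S(=O)(=O)/C(=C/c2ccc(C)s2)C(=O)c2ccc(Cl)cc2)cc1`: 25000 nM
- compound 3 `Cc1ccc(/C=C(\C(=O)c2ccc(Cl)cc2)S(=O)(=O)Cc2ccc(Cl)cc2Cl)s1`: 10000 nM

Compound 3 holds the lowest number of the three, while compound 1 and compound 2 read the same higher value. Next in line is compound 4 `Cc1ccc(CS(=O)(=O)/C(=C/c2ccc(C)s2)C(=O)c2ccc(Cl)cc2)cc1`, which carries 4-methylbenzyl in place of the 2,4-dichlorobenzyl of compound 3: 4-methylphenyl in place of 2,4-dichlorophenyl on a saturated chain carbon bound to a sulfonyl sulfur.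

Among the compounds with values here, one measured step touches this part of the structure: a 2.5-fold lower number from compound 2 to compound 3 (0.40 log units; beyond the scatter), a modest step obtained by introducing 2,4-dichlorobenzyl in place of 4-methoxyphenyl on the sulfonyl sulfur. It starts from a different group, so it offers only indirect guidance. The 4-methylbenzyl group also occurs in compound 1 at 25000 nM, although that compound departs from compound 4 elsewhere. Together these point to a modest move towards a higher number in this assay, with 2,4-dichlorobenzyl given up. The estimated step is a 1.8-fold higher number from compound 3 to compound 4 (0.26 log units; within the scatter). For compound 4 the expected value is 18000 nM, with an estimated range of 8000 nM to 40000 nM.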

Compound 4, concentration for 50% growth inhibition: 25000 nM
The estimate for compound 4 lay 1.4-fold (0.14 log units) below the measured number, and the stated range covers the measured number.
By their numbers in this assay, from the lowest: compound 3; then compounds 1, 2 and 4 (each within the scatter of the next).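

In this assay, the direct pair shows that this position responds to the aryl group: 4-methylphenyl in place of 2,4-dichlorophenyl on a saturated chain carbon bound to a sulfonyl sulfur gives a 2.5-fold higher number from compound 3 to compound 4 (0.40 log units; beyond the scatter). The lower number of compound 3 therefore does not carry over to 4-methylbenzyl, and 4-methylbenzyl in place of 4-methoxyphenyl on a sulfonyl sulfur gives no change at the digits printed from compound 2 to compound 4 (within the scatter). With 4-methylbenzyl held fixed, 5-methylthiophen-2-yl in place of 4-bromophenyl on a double-bonded chain carbon bound to a double-bonded chain carbon gives no change at the digits printed from compound 1 to compound 4 (within the scatter).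

Nothing available accounts for the step between the two benzyl groups. Still open, as far as these compounds go, is whether 4-chlorobenzyl, or a benzyl group carrying an amine or a carboxylic acid, would read nearer to compound 3 or to compound 4 in this assay.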